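From 4-bromophenyl to 1-methyl-1H-pyrazol-3-yl at the chain carbon

A few compounds are considered here, and "the series" means these few. Any claim that something is new, unique, unknown or untested is made for them only; others in the source may bear on it.

In an ADME assay on microsomes from liver (Homo sapiens) for metabolic stability (a higher number here means faster removal of the compound, a lower number slower removal), compound 1 `Cc1cccc([C@H](C)NC(=O)Cn2nnc3ccccc3c2=O)c1` gives 11 mL/min/kg and carries 3-methylphenyl. Compound 2 `C[C@H](NC(=O)Cn1nnc2ccccc2c1=O)c1ccc(Br)cc1` gives < 9.9 mL/min/kg in this assay and so stands at a limit of the assay, not at a number. Going by the values given here, the only measured step at this place is an at least 1.1-fold lower number from compound 1 to compound 2 (0.04 log units; that floor lies within the scatter) and it exchanges 3-methylphenyl for 4-bromophenyl. How far that step really reaches is not known.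

Compound 3 `C[C@H](NC(=O)Cn1nnc2ccccc2c1=O)c1ccn(C)n1` brings 1-methyl-1H-pyrazol-3-yl in place of 4-bromophenyl on a saturated chain carbon bound to an amide-type nitrogen and a saturated chain carbon, and 1-methyl-1H-pyrazol-3-yl in place of 4-bromophenyl on a saturated chain carbon bound to an amide-type nitrogen and a saturated chain carbon sets out what is exchanged. Among the compounds with values here, no compound measured so far carries a five-membered aromatic ring with 2 hetero atoms at this place, so the guidance is thin. Resting on an at least 1.1-fold lower number from compound 1 to compound 2 (0.04 log units; that floor lies within the scatter) as the only guide, the expected size of the change is a number no lower from compound 2 to compound 3 (the limit leaves the size open) and no shift beyond the scatter is foreseen. For compound 3 the estimate is 10 mL/min/kg in this assay with an expected range from 7 mL/min/kg to 16 mL/min/kg as the likely span of measurements.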

Compound 3, clearance: 12 mL/min/kg
For compound 3 the middle estimate is 1.2-fold (0.08 log units) below the measured one, within the range that was stated.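

In this assay, the exchange of 3-methylphenyl for 1-methyl-1H-pyrazol-3-yl on a saturated chain carbon bound to an amide-type nitrogen and a saturated chain carbon gives a 1.1-fold higher number from compound 1 to compound 3 (0.04 log units; within the scatter). Unlike the step to compound 2, this one joins two actual numbers, so it shows for this pair that a five-membered aromatic ring with 2 hetero atoms can take the place of a six-membered aromatic ring of carbon only with no shift beyond the scatter. The exchange of 4-bromophenyl for the same group reads an at least 1.2-fold higher number from compound 2 to compound 3 (0.08 log units; that floor lies within the scatter), and that figure is only a floor, its true size remaining unknown because one end of the step is a limit of the assay: the limit of < 9.9 mL/min/kg in this assay, at which 1 of the 3 values shown sits.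

The compounds shown leave open how far compound 2 really lies from compound 3, and whether any group at this place can move the number in this assay beyond the scatter. They also leave open what a carboxylic acid or an aminomethyl group on this ring would do to that number.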